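Notes on the aryl substituent of the shared core

A few compounds are considered here, and "the series" means these few. Any claim that something is new, unique, unknown or untested is made for them only; others in the source may bear on it.

Compound 3 `FC(F)(F)c1ccc(-c2csc(N3N=C(c4ccc(N5CCCCC5)cc4)CC3c3ccc(Cl)cc3)n2)cc1` gives 42000 nM in a functional assay on A549 cells (Homo sapiens) for antiproliferative activity, read by MTT assay, with a stated time of 72 h; on this read-out higher numbers stand for weaker inhibition and lower numbers for stronger inhibition. Compound 2 `Clc1ccc(C2CC(c3ccc(N4CCCCC4)cc3)=NN2c2nc(-c3ccc(Br)cc3)cs2)cc1` gives 39700 nM in this assay, and the two values sit within the scatter of each other, so compound 3 stands alongside compound 2 rather than apart from it. For compound 1 `O=[N+]([O-])c1ccc(-c2csc(N3N=C(c4ccc(N5CCCCC5)cc4)CC3c3ccc(Cl)cc3)n2)cc1` only a limit is reported in this assay, namely > 100000 nM (the limit of > 100000 nM in this assay, at which 1 of the 3 values shown sits). Measured from that limit, the steps read an at least 2.5-fold lower number from compound 1 to compound 2 (0.40 log units; beyond the scatter) and an at least 2.3-fold lower number from compound 1 to compound 3 (0.37 log units; beyond the scatter); between the two numbered compounds the step is a 1.1-fold higher number from compound 2 to compound 3 (0.02 log units; within the scatter).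

Compound 4 `Cc1ccc(-c2csc(N3N=C(c4ccc(N5CCCCC5)cc4)CC3c3ccc(Cl)cc3)n2)cc1` differs from compound 3 by methyl in place of trifluoromethyl on an aromatic carbon. Among the measured compounds shown here, no measured step exchanges trifluoromethyl or bromo for methyl. For the measured compounds named here, the only step between two numbered values, a 1.1-fold higher number from compound 2 to compound 3 (0.02 log units; within the scatter), lies within the scatter, and the steps away from the limit of compound 1 are at least modest but carry no number to build on. The expectation for compound 4 in this assay is therefore a step of a 1.1-fold higher number from compound 3 to compound 4 (0.03 log units; within the scatter), none beyond the scatter. Compound 4 is estimated at 45000 nM, with a range from 18000 nM to 110000 nM, and some chance that only a limit is returned.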

Compound 4, half-maximal inhibitory concentration: > 100000 nM
Compound 4: only a limit was reported (the forecaster's own chance of this, stated with the estimate: 20%); middle value at least 2.2-fold (0.34 log units) away from the limit.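

Before this result, the only step between two numbers, a 1.1-fold higher number from compound 2 to compound 3 (0.02 log units; within the scatter), showed no separation at this position. Methyl in place of trifluoromethyl now gives an at least 2.3-fold higher number from compound 3 to compound 4 (0.37 log units; beyond the scatter), and methyl in place of bromo gives an at least 2.5-fold higher number from compound 2 to compound 4 (0.40 log units; beyond the scatter), so the group on this aromatic carbon does change the read-out in this assay. Among the four groups, bromo in compound 2 and trifluoromethyl in compound 3 return numbers, while nitro in compound 1 and methyl in compound 4 return only a limit, and the step between those two cannot be read: the limit of > 100000 nM in this assay, at which 2 of the 4 values shown sit.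

On these data alone, whether a methoxy group, an amine or a carboxylic acid on this carbon would return a number stays open. As far as these compounds go, it also stays open whether any group here would bring the values of compound 2 and compound 3 down further.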